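Swapping a bromo for a hydroxy on a naphthyloxy hydrazide

The compounds below may be only part of what the source reports. "The series", "measured", "known", "first", "only" and "open" are said of these compounds alone.

Of the compounds shown here, three sharing one core have been measured in a physicochemical assay for lipophilicity, measured as octanol-water partition; a higher number here means a more lipophilic compound, a lower number a more polar compound. Compound 1 `C/C(=N\NC(=O)COc1cccc2ccccc12)c1ccc(C#N)cc1Br` gives 3.61. Compound 2 `O=C(COc1cccc2ccccc12)N/N=C/c1ccccc1Br` gives 4.81, the highest of the three numbers, standing beyond the scatter above both of the others. Compound 3 `COc1ccc(/C=N/NC(=O)COc2cccc3ccccc23)cc1O` gives 3.48, the lowest number of the set. Among the compounds with values here, no pair among the three differs in a single place, so no measured step is available.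

Compound 4 `O=C(COc1cccc2ccccc12)N/N=C/c1ccccc1O` has not yet been measured in this assay. It differs from compound 2 in one place: hydroxy in place of bromo on an aromatic carbon. Since the group that enters carries one hydrogen-bond donor and one hydrogen-bond acceptor where the bromo carried none, the expected step from compound 2 to compound 4 is a number 1.31 log units lower from compound 2 to compound 4 (beyond the scatter), a decrease well beyond the scatter. On that basis the value of compound 4 in this assay is estimated at 3.5, with a range from 2.9 to 4.1.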

Compound 4, partition coefficient: 3.73
Beside the measured number, compound 4's estimate is 0.23 log units below it; measured number inside the range.
By their numbers in this assay, from the lowest: compounds 3, 1 and 4 (each within the scatter of the next); then compound 2.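

Hydroxy in place of bromo on an aromatic carbon, ortho to a large group, gives a number 1.08 log units lower from compound 2 to compound 4 (beyond the scatter) in this assay, the first reading of a single change on the shared core. It shows that the high number of compound 2 is sensitive to this one substituent, with the rest of the molecule held the same. Nothing in the data shown accounts for the size of this step.

The compounds shown leave open whether the same exchange would give a step of similar size at another place on this ring. They also leave open where other groups at this position, such as an amine, a fluoro or a carboxylic acid, would fall relative to the bromo and the hydroxy.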